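The compounds below may be only part of what the source reports. "The series", "measured", "known", "first", "only" and "open" are said of these compounds alone.

Measured compounds:
Compound 1 `CCC(Oc1cc(C)nc2ccc(OC)cc12)C(=O)Nc1cc(C)cc(C)c1`: 123000 nM
Compound 2 `COc1ccc2nc(C)cc(OCC(=O)Nc3cccc(C)c3)c2c1`: 193000 nM

In a physicochemical assay for solubility, in phosphate buffer, measured as kinetic solubility, with a stated time of 1 h, at pH 7.4 (on this read-out lower numbers stand for lower solubility and higher numbers for higher solubility), compound 2 gives 193000 nM, the highest of the two numbers recorded. Its nearest neighbour is compound 1, which in this assay gives 123000 nM; that gap lies within the scatter, so the two compounds cannot be put in any order on this read-out.

Compound 3 `COc1ccc2nc(C)cc(OCC(=O)NC3CONC3=O)c2c1` has not yet been measured. It differs from compound 2 in one place: a group of 6 heavy atoms (3 carbon, 1 nitrogen, 2 oxygen; one five-membered non-aromatic ring with 2 hetero atoms) in place of a group of 7 heavy atoms (7 carbon; one six-membered aromatic ring of carbon only), on an amide-type nitrogen. The 3-methylphenyl group leaves, and the five-membered non-aromatic ring with two hetero atoms, which carries one hydrogen-bond donor and two hydrogen-bond acceptors, enters on the amide-type nitrogen.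

For the measured compounds named here, no step between two measured compounds is available here that would show how a change of this kind plays out in this assay. Resting on the structural change alone, the expected step of a 2.1-fold higher number from compound 2 to compound 3 (0.32 log units; beyond the scatter) points upward and beyond the scatter. Compound 3 is therefore estimated at 400000 nM, with a range from 180000 nM to 900000 nM, and a measurement this high may come back as a limit of the assay rather than a number.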

Compound 3, solubility: >= 166000 nM
Compound 3 ended at the assay's limit; the forecaster's own chance of this, stated with the estimate: 30%; the middle value is on the limit's open side.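

In this assay compound 3 gives >= 166000 nM, which is a limit of the assay and not a number. The step between compound 2 and compound 3 therefore cannot be read: the limit of >= 166000 nM in this assay, at which 1 of the 3 values shown sits.

The compounds shown leave open whether the value of compound 3 differs from that of compound 2 at all, and in which direction.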